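Methylating the phenol in a urea series

This account rests on a few compounds, and the source may have more. Where it says the series, first, only, none or still open, it means among the compounds named here.

Three compounds sharing one core were tested in a functional assay on RPMI-8226 cells (Homo sapiens) for inhibition, read by sulforhodamine B assay, with a stated time of 48 h, tested at 0.01 uM; on this read-out higher numbers stand for a weaker effect at the one concentration tested and lower numbers for a stronger effect. Compound 1 `O=C(Nc1cccc(-n2cc(-c3ccncc3)c(-c3cc(O)cc(Cl)c3)n2)c1)Nc1ccc(Cl)c(C(F)(F)F)c1` gives 101%. Compound 2 `O=C(Nc1cccc(-n2cc(-c3ccncc3)c(-c3cc(O)cc(Cl)c3)n2)c1)Nc1ccc(Cl)c(Cl)c1` gives 104%. Compound 3 `COc1cc(Cl)cc(-c2nn(-c3cccc(NC(=O)Nc4cc(C(F)(F)F)cc(C(F)(F)F)c4)c3)cc2-c2ccncc2)c1` gives 93%. Going by the values given here, compound 2 holds the highest of the three numbers: compound 1 lies within the scatter of it, while compound 3 lies beyond the scatter, though compound 3 differs from compound 2 in two places and no single step links them. Among the compounds with values here, the one measured step, a number 3 percentage points higher from compound 1 to compound 2 (within the scatter), came with chloro in place of trifluoromethyl on an aromatic carbon and left the read-out within the scatter.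

Compound 4 `COc1cc(Cl)cc(-c2nn(-c3cccc(NC(=O)Nc4ccc(Cl)c(Cl)c4)c3)cc2-c2ccncc2)c1` is not yet measured. It differs from compound 2 by methyl in place of hydrogen on an oxygen on an aromatic ring; cut one bond further out, the change reads hydroxy to methoxy, or 3-chloro-5-hydroxyphenyl to 3-chloro-5-methoxyphenyl. Within the data shown here, no measured step isolates this change. Compound 3 carries the methoxy group and sits at 93%, but its other end also differs from compound 2, so it offers only a loose hint. The step of a number 3 percentage points higher from compound 1 to compound 2 (within the scatter) shows the series absorbing one change without moving beyond the scatter. The expected step of a number 6 percentage points lower from compound 2 to compound 4 (within the scatter) is therefore small, at most a slight drift downward. Compound 4 is estimated at 98%, within a range of 86% to 110%.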

Compound 4, a percentage reported as activity, at one concentration (the size of the read-out at that concentration, not a potency): 99%
Compound 4: middle estimate off by 1 percentage points, on the low side; the measured number falls inside the stated range.
By their numbers in this assay, from the lowest: compounds 3, 4, 1 and 2 (each within the scatter of the next, the first and the last beyond it).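

In this assay, the change from hydroxy to methoxy on the 3-chloro-5-hydroxyphenyl group can now be read on its own, and it gives a number 5 percentage points lower from compound 2 to compound 4 (within the scatter). Methyl in place of hydrogen on this oxygen therefore leaves compound 4 indistinguishable from its phenol partner at the one concentration tested, something compound 3 could only hint at, as it also differs from compound 2 at its other end. No measurement shown here offers an explanation for this result.

The compounds shown leave open whether this position would also accept something larger or of another kind, such as an ethoxy group, a longer ether chain, an amine or a carboxylic acid. They also leave open whether hydroxy and methoxy would remain this close with the other urea ends seen in compound 1 and compound 3, or at concentrations other than the single one tested, where the read-outs of compound 2 and compound 4 might or might not separate.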